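Azetidin-1-yl in place of dimethylamino: compound 1 to compound 4

A few compounds are considered here, and "the series" means these few. Any claim that something is new, unique, unknown or untested is made for them only; others in the source may bear on it.

Within the data shown here, compound 1 `CCCCCCCCCCCCCCCCc1c(C)c(N(C)C)nc(C)c1O` gives 80% in a functional assay on cells (Lymphocyte), read by a luciferase reporter and ATP content, with a stated time of 48 h, tested at 10 uM (on this read-out lower numbers stand for a stronger effect and higher numbers for a weaker effect at the one concentration tested), the highest of the three numbers measured so far. Compound 2 `CCCCCCCCCCc1c(C)c(N(C)C)nc(C)c1O` gives 40%, and compound 3 `Cc1c(N(C)C)nc(CCCCCCCCCCO)c(O)c1C` gives 20%; the nearest to compound 1 is compound 2 and the furthest is compound 3. Among the measured compounds shown here, the only measured step, a number 40 percentage points lower from compound 1 to compound 2 (beyond the scatter), concerns the saturated chain alone.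

For the measured compounds named here, compound 4 `CCCCCCCCCCCCCCCCc1c(C)c(N2CCC2)nc(C)c1O` remains untested. azetidin-1-yl in place of dimethylamino on an aromatic carbon The dimethylamino group is shared by compounds 1, 2 and 3, so no measured step bears on this change; the one step in hand, a number 40 percentage points lower from compound 1 to compound 2 (beyond the scatter), alters a different part of the molecule and gives no guide to the ring nitrogen substituent. With nothing in the set pointing in either direction, no step beyond the scatter is expected, and the estimated step is no change at the digits printed from compound 1 to compound 4 (within the scatter). Compound 4 is therefore expected to give about 80% in this assay, with an estimated range from 55% to 100%; the range is wide because only compound 1 with 80% anchors it.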

Compound 4, a percentage reported as activity, at one concentration (the size of the read-out at that concentration, not a potency): 76%
Estimate against measurement, compound 4: 4 percentage points above; the range from low to high includes it.
By their numbers in this assay, from the lowest: compound 3; then compound 2; then compounds 4 and 1 (each within the scatter of the next).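

In this assay, among these compounds, azetidin-1-yl in place of dimethylamino on an aromatic carbon gives a number 4 percentage points lower from compound 1 to compound 4 (within the scatter) and is the first reading at this position. On the long chain of compound 1, a four-membered non-aromatic ring can therefore replace the open dimethylamino group without a step beyond the scatter. No measurement shown accounts for this outcome.

Going by these compounds, it remains open whether the same change would also stay within the scatter on the shorter chain of compound 2, which gives 40%, or on the hydroxy-ended chain of compound 3, which gives 20%. Also open, on these data alone, is how a larger ring such as pyrrolidin-1-yl or morpholin-4-yl, or a primary amine, would read at this position.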